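Phenoxy in Place of Sulfamoyl on a Shared Core

The source may report more compounds than this note shows. Statements on the series, on what has been measured and on what is new or still open speak of the compounds shown alone.

Compound 1 `COc1ccc(-c2ccc(NC3=CC(=O)c4ncncc4C3=O)cc2)cc1` carries a 4-methoxyphenyl group on its aromatic ring and gives 3500 nM in a functional assay on BXPC-3 cells (Homo sapiens) for cytotoxicity, read by MTT assay, with a stated time of 72 h; a higher number here means a weaker inhibitor, a lower number a stronger inhibitor. Compound 2 `NS(=O)(=O)c1ccc(NC2=CC(=O)c3ncncc3C2=O)cc1` carries sulfamoyl at that position instead. In this assay compound 2 reaches only the limit of > 10000 nM, so no number is known for it. The step of an at least 2.8-fold higher number from compound 1 to compound 2 (0.45 log units; beyond the scatter) therefore has only a lower bound, as noted in the limit of > 10000 nM in this assay, at which 1 of the 2 values shown sits.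

Compound 3 `O=C1C(Nc2ccc(Oc3ccccc3)cc2)=CC(=O)c2ncncc21` is the next member: phenoxy in place of sulfamoyl on an aromatic carbon. Among the compounds with values here, this restores an aromatic ring at the position that compound 1 also fills with an aromatic ring, and the only measured step bearing on it is an at least 2.8-fold higher number from compound 1 to compound 2 (0.45 log units; beyond the scatter), which moved the number upward when the aromatic ring was removed. Reversing that direction with a phenoxy group is expected to bring the number back down, broadly toward the level of compound 1.

On that basis compound 3 is estimated at 4000 nM in this assay, within 1500 nM to 12000 nM, which corresponds to an expected step of an at least 2.5-fold lower number from compound 2 to compound 3 (0.39 log units; beyond the scatter) from the limit of compound 2.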

Compound 3, half-maximal inhibitory concentration: 3600 nM
For compound 3 the middle estimate is 1.1-fold (0.05 log units) above the measured one, within the range that was stated.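

The phenoxy group shows that the loss seen with sulfamoyl at this position can be reversed by a group other than 4-methoxyphenyl: in this assay there is an at least 2.7-fold lower number from compound 2 to compound 3 (0.44 log units; beyond the scatter) when phenoxy replaces sulfamoyl on the aromatic carbon. The comparison with the first aromatic group gives a 1.0-fold higher number from compound 1 to compound 3 (0.01 log units; within the scatter) and so does not separate phenoxy from 4-methoxyphenyl, even though the two groups differ in how their outer aromatic ring is attached. On these data alone, for compound 2 the value > 10000 nM is a limit and not a number, so the true size of the step from sulfamoyl to phenoxy stays unknown and only its lower bound can be read: the limit of > 10000 nM in this assay, at which 1 of the 3 values shown sits.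

With only three groups shown at this one position, the compounds cannot tell whether an outer aromatic ring is what matters or whether other groups would match phenoxy and 4-methoxyphenyl. A simple amine, a carboxylic acid, a longer alkyl chain or a pyridine ring in the same place would test this, and a substituent on the phenoxy ring would show how much change the outer ring tolerates.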